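The source may report more compounds than this note shows. Statements on the series, on what has been measured and on what is new or still open speak of the compounds shown alone.

The measured compounds:
Compound 1, `O=C1CSC(c2cccc(O)c2)N1CCN1CCCCC1`: 11%
Compound 2, `O=C1CSC(c2ccc(O)cc2)N1CCN1CCCCC1`: 10%
Compound 3, `Cc1ccc(C2SCC(=O)N2CCN2CCCCC2)cc1`: 12%

All three were tested in an ADME assay on Vero cells (Chlorocebus sabaeus) for cytotoxicity, read by neutral red uptake, tested at 3150 ug/mL; on this read-out higher numbers stand for a weaker effect at the one concentration tested and lower numbers for a stronger effect. They share one core and differ only in the aromatic group attached to a saturated ring carbon. Compound 3 carries a 4-methylphenyl there, and its value sits together with the other two: the step of a number 1 percentage points higher from compound 1 to compound 3 (within the scatter) and the step of a number 2 percentage points higher from compound 2 to compound 3 (within the scatter) are both within the scatter, as is the step of a number 1 percentage points lower from compound 1 to compound 2 (within the scatter). Compound 4, `O=C1CSC(c2cccc(F)c2)N1CCN1CCCCC1`, has not yet been measured in this assay. It differs from compound 3 in one place: 3-fluorophenyl in place of 4-methylphenyl on a saturated ring carbon. Among the compounds with values here, no measured step exchanges a methyl for a fluorine, so the only guide is that every change of the aromatic group seen so far left the read-out within the scatter. A step of a number 1 percentage points lower from compound 3 to compound 4 (within the scatter) of no size beyond the scatter is therefore expected. Compound 4 is estimated to give 11%, within a range from 4% to 22%.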

Compound 4, a percentage reported as activity, at one concentration (the size of the read-out at that concentration, not a potency): 13%
Compound 4: middle estimate off by 2 percentage points, on the low side; the measured number falls inside the stated range.
By their numbers in this assay, from the lowest: compounds 2, 1, 3 and 4 (each within the scatter of the next).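

Within the data shown here, this is the first halogen on the aromatic ring, and in this assay 3-fluorophenyl in place of 4-methylphenyl gives a number 1 percentage points higher from compound 3 to compound 4 (within the scatter). Set against the two hydroxyphenyl compounds, the 3-fluorophenyl group gives a number 2 percentage points higher from compound 1 to compound 4 (within the scatter), and 3-fluorophenyl in place of 4-hydroxyphenyl gives a number 3 percentage points higher from compound 2 to compound 4 (within the scatter), so all four aromatic groups shown lie within the scatter of one another. Nothing measured here bears on why these groups read alike.

Every group shown at this position is a phenyl ring with one small substituent, so it remains open whether a carboxylic acid, a dimethylamino group or a longer alkyl chain on that ring would give a step beyond the scatter. The compounds also leave open whether a pyridine ring in place of the phenyl ring, or any change to the shared core, would do so.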